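A Single Fluorine Added at the Edge of Compound 2

The source may hold more compounds than are shown below. What is called first, only, known or untested is meant among the compounds shown, and "the series" means these compounds.

Compound 1, `COc1ccc(-c2cc(C(C)=O)c3[nH]c(-c4ccc(F)cc4)cc3c2)cc1`: 56.1%
Compound 2, `CC(=O)c1cc(/C=C/c2ccccc2)cc2cc(-c3ccccc3)[nH]c12`: 79.8%

Both compounds were tested in a functional assay on HeLa cells (Homo sapiens) for cytotoxicity, read by MTT assay, with a stated time of 2 days, tested at 1 uM; a higher number here means a weaker effect of the compound at the concentration tested, a lower number a stronger effect. Of the two numbers, compound 2 stands highest, and its nearest neighbour, compound 1, lies lower by a margin beyond the usual scatter, so compound 2 shows the weaker effect of the two at this concentration. Compound 3, `CC(=O)c1cc(/C=C/c2ccccc2)cc2cc(-c3ccc(F)cc3)[nH]c12`, has not yet been measured. It differs from compound 2 in one place: fluoro in place of hydrogen on an aromatic carbon. Cut one bond further out, the change reads phenyl to 4-fluorophenyl. Going by the values given here, no pair of measured compounds differs only in this one place, so the size of this change cannot be read from the data at hand. A small step is expected, downward if any, and most likely within the scatter. For compound 3 a value of 75% is estimated, lying between 60% and 90%. That estimate corresponds to an expected step of a number 4.8 percentage points lower from compound 2 to compound 3 (within the scatter).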

Compound 3, a percentage reported as activity, at one concentration (the size of the read-out at that concentration, not a potency): 60.5%
The estimate for compound 3 lay 14.5 percentage points above the measured number; low and high end bracket the measured number.
By their numbers in this assay, from the lowest: compounds 1 and 3 (each within the scatter of the next); then compound 2.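

In this assay, fluoro in place of hydrogen on an aromatic carbon, para to a large group, gives a number 19.3 percentage points lower from compound 2 to compound 3 (beyond the scatter), so this single added atom is enough to strengthen the effect at the concentration tested. Compound 3 also allows a second comparison: 2-phenylethenyl in place of 4-methoxyphenyl on an aromatic carbon gives a number 4.4 percentage points higher from compound 1 to compound 3 (within the scatter), so with 4-fluorophenyl present, these two groups cannot be told apart in this assay. Nothing measured here explains why the change from phenyl to 4-fluorophenyl has this effect.

On these data alone, whether another group at the same place, such as chloro, an amine or a carboxylic acid, would shift the number further remains open. So does whether the step from phenyl to 4-fluorophenyl would hold with 4-methoxyphenyl in place of 2-phenylethenyl.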